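This account rests on a few compounds, and the source may have more. Where it says the series, first, only, none or still open, it means among the compounds named here.

Compound 1 `COc1ccc(-c2ccc3c(c2)C(=O)C(=O)N3Cc2ccc(Cl)c(Cl)c2)cc1`: 430 nM
Compound 2 `COc1ccc(CN2C(=O)C(=O)c3cc(-c4ccc(OC)cc4)ccc32)cc1`: 30 nM

Both values come from a functional assay on K562 cells (Homo sapiens) for antiproliferative activity, read by MTT assay, with a stated time of 48 h (on this read-out higher numbers stand for weaker inhibition and lower numbers for stronger inhibition), where compound 2 at 30 nM gives the lower of the two numbers. Compound 3 `COc1ccc(-c2ccc3c(c2)C(=O)C(=O)N3Cc2ccccc2OC)cc1` differs from compound 2 as follows: 2-methoxyphenyl in place of 4-methoxyphenyl on a saturated chain carbon bound to an amide-type nitrogen in a ring. Going by the values given here, the only measured step at this place, with 4-methoxyphenyl in place of 3,4-dichlorophenyl, is large: a 14-fold lower number from compound 1 to compound 2 (1.16 log units; beyond the scatter). That step shows the place can matter in this assay, but no measurement covers the present change itself. A moderate rise is therefore expected, with the estimated step being a 3.3-fold higher number from compound 2 to compound 3 (0.52 log units; beyond the scatter). Compound 3 is estimated at 100 nM, with an expected range of 30 nM to 350 nM.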

Compound 3, half-maximal inhibitory concentration: 40 nM
Compound 3: middle estimate off by 2.5-fold (0.40 log units), on the high side; measured number inside the range.
By their numbers in this assay, from the lowest: compounds 2 and 3 (each within the scatter of the next); then compound 1.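

In this assay, the step of a 1.3-fold higher number from compound 2 to compound 3 (0.12 log units; within the scatter) stays within the scatter, so 2-methoxyphenyl and 4-methoxyphenyl cannot be told apart on the saturated chain carbon bound to an amide-type nitrogen in a ring. The step of an 11-fold lower number from compound 1 to compound 3 (1.03 log units; beyond the scatter) is also large, so the gap to 3,4-dichlorophenyl at this place is seen with either of these two methoxyphenyl groups. No evidence on hand accounts for either result.

Still open, from the compounds shown here alone, is whether 3-methoxyphenyl or unsubstituted phenyl matches these two methoxyphenyl groups. Going by these compounds, a single chlorine, as in 4-chlorophenyl, or an amine such as 4-dimethylaminophenyl also remains open.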